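The source may report more compounds than this note shows. Statements on the series, on what has been measured and on what is new or still open speak of the compounds shown alone.

Measured so far:
compound 1, `CCN1CCN(c2cc(C)c3cc(NC(=O)c4ccccc4)ccc3n2)CC1`, 18400 nM in a functional assay on SK-BR-3 cells (Homo sapiens) for antiproliferative activity, read by MTT assay, with a stated time of 72 h; a lower number here means a stronger inhibitor, a higher number a weaker inhibitor
compound 2, `Cc1cc(N2CCN(C(C)C)CC2)nc2ccc(NC(=O)c3ccc(Cl)c(Cl)c3)cc12`, 6680 nM in this assay

Compound 1 gives the highest of the two numbers; compound 2 gives the lower one, a gap that lies beyond the scatter. Compound 3, `CCN1CCN(c2cc(C)c3cc(NC(=O)c4ccccc4Cl)ccc3n2)CC1`, has not yet been measured in this assay. It differs from compound 1 by chloro in place of hydrogen on an aromatic carbon. Going by the values given here, no measured pair tells how this change alone moves the number, so the expected step from compound 1 to compound 3 is set at a 1.5-fold lower number from compound 1 to compound 3 (0.19 log units; within the scatter), a modest lowering that may not exceed the scatter. Compound 3 is estimated at 12000 nM, within 5000 nM to 30000 nM.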

Compound 3, half-maximal inhibitory concentration: > 50000 nM
Compound 3: a limit, no number; the forecaster's own chance of this, stated with the estimate: 5%; at least 4.1-fold (0.61 log units) between middle value and limit.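

Compound 3 gives no number in this assay, only a limit of the assay: the limit of > 50000 nM in this assay, at which 1 of the 3 values shown sits.

Chloro in place of hydrogen on an aromatic carbon, ortho to a large group, brings an at least 2.7-fold higher number from compound 1 to compound 3 (0.43 log units; beyond the scatter). Going by these compounds alone, this is the first direct reading of a single change at this position, and it weakens the compound; compound 1 and compound 2 differ in more than one place and could not show this.

The compounds shown leave open whether fluoro, methyl or methoxy in this same position would also raise the number.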